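Trimming a Propyl Tail While Watching Vero Cell Cytotoxicity

The source may hold more compounds than are shown below. What is called first, only, known or untested is meant among the compounds shown, and "the series" means these compounds.

Compound 1 `CCCc1ccc(C(=O)Nc2cc3nc(C4CCCCC4)[nH]c3cc2N(C)C)cc1` carries a propyl chain. In an ADME assay on Vero cells (Chlorocebus sabaeus) for cytotoxicity, read by resazurin assay, with a stated time of 3 days (a higher number here means a weaker inhibitor, a lower number a stronger inhibitor), compound 1 gives only a limit, > 100 ug/mL, so no single number is known for it. A close sibling, compound 2 `CCCc1ccc(C(=O)Nc2cc3nc(C4CCCCC4)[nH]c3cc2N(CC)CC)cc1`, has "not determined" (no result reported) in this assay. Among the measured compounds shown here, compound 1 thus stands at the limit of > 100 ug/mL in this assay, at which 1 of the 2 values shown sits, and no measured step between compounds exists to lean on. Compound 3 `Cc1ccc(C(=O)Nc2cc3nc(C4CCCCC4)[nH]c3cc2N(C)C)cc1` differs from compound 1 by hydrogen in place of ethyl on a saturated chain carbon bound to an aromatic carbon. The step is expected to be a step that the limit leaves unreadable from compound 1 to compound 3, no larger than the scatter. Compound 3 is therefore expected to show about 120 ug/mL in this assay, most likely between 60 ug/mL and 250 ug/mL.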

Compound 3, half-maximal inhibitory concentration: > 100 ug/mL
Compound 3 ended at the assay's limit (the forecaster's own chance of this, stated with the estimate: 80%); the middle value lies beyond the limit too.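

No step can be read between compound 1 and compound 3 in this assay: each gives only a limit, not a number. The compounds shown leave open whether going from propyl to methyl changes cytotoxicity at all.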